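Working notes: adding bromo to the benzyl group of compound 3

This account rests on a few compounds, and the source may have more. Where it says the series, first, only, none or still open, it means among the compounds named here.

Of the compounds shown here, three on the shared core have been read so far in a functional assay on Bel-7402 cells (Homo sapiens) for antiproliferative activity, read by MTT assay, with a stated time of 72 h; on this read-out higher numbers stand for weaker inhibition and lower numbers for stronger inhibition. Compound 1 (`C=C1C(=O)O[C@H]2[C@H]1CC/C(COC(=O)CCC(=O)NCCCCCCNC(=O)Cn1cc(F)c(=O)[nH]c1=O)=C\CC[C@@]1(C)O[C@@H]21`) gives > 20000 nM and this is a limit of the assay. Compound 2 (`C=C1C(=O)O[C@H]2[C@H]1CC/C(COC(=O)CCC(=O)N1CCN(C(=O)Cn3cc(F)c(=O)[nH]c3=O)CC1)=C\CC[C@@]1(C)O[C@@H]21`) gives > 20000 nM and this too is a limit of the assay. Among the compounds with values here, compound 3 (`C=C1C(=O)O[C@H]2[C@H]1CC/C(COC(=O)Cn1cc(F)c(=O)n(Cc3ccccc3)c1=O)=C\CC[C@@]1(C)O[C@@H]21`) gives 3980 nM as the only actual number in the set, so it has no numeric value to be ranked against.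

Compound 4 (`C=C1C(=O)O[C@H]2[C@H]1CC/C(COC(=O)Cn1cc(F)c(=O)n(Cc3ccc(Br)cc3)c1=O)=C\CC[C@@]1(C)O[C@@H]21`) differs from compound 3 by bromo in place of hydrogen on an aromatic carbon in that benzyl becomes 4-bromobenzyl, with the bromo para to a large group. Within the data shown here, no measured pair shows what a substituent on this ring does, so the expectation rests on compound 3 at 3980 nM alone. A small move toward stronger inhibition in this assay is expected, amounting to an estimated 1.3-fold lower number from compound 3 to compound 4 (0.12 log units; within the scatter) and not clearly beyond the scatter. For compound 4 the estimate is 3000 nM (expected range 1200 nM to 9000 nM).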

Compound 4, half-maximal inhibitory concentration: 2670 nM
Estimate against measurement, compound 4: 1.1-fold (0.05 log units) above; low and high end bracket the measured number.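

In this assay, the first substituent seen on this benzyl ring gives a 1.5-fold lower number from compound 3 to compound 4 (0.17 log units; within the scatter). Bromo in place of hydrogen on an aromatic carbon, para to a large group, therefore leaves the two compounds reading alike, which shows that this position accepts a bromine atom with the value still inside the measurable range of this assay. This single step gives no direction for the position, and the rest of the series adds no number to set beside it: the limit of > 20000 nM in this assay, at which 2 of the 4 values shown sit.

Going by these compounds, whether an amine or a carboxylic acid in the same place would read differently from bromo remains open. Also open, on these data alone, is whether a longer chain in place of the benzyl group would move the value beyond the usual scatter of this assay.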